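The compounds below may be only part of what the source reports. "The series", "measured", "known", "first", "only" and "open" are said of these compounds alone.

Four compounds share one core and differ at a few places. Compound 1 `CCCN1CCN(CCNC(=O)n2c(=O)n(C3CC3)c3ccccc32)CC1`, compound 2 `CCN1CCN(CCNC(=O)n2c(=O)n(C(C)C)c3ccccc32)CC1` and compound 3 `CC(C)n1c(=O)n(C(=O)NCCCN2CCN(C)CC2)c2ccccc21` have been measured in a functional assay for antagonist activity at 5-hydroxytryptamine receptor 4 (Cavia porcellus); a lower number here means a less potent compound, a higher number a more potent compound, by a factor of ten per unit of this negative logarithm; compound 4 `CN1CCN(CCCNC(=O)n2c(=O)n(C3CC3)c3ccccc32)CC1` has not. Compound 1 gives 7.46 and compound 2 gives 6.62, but these two differ at more than one place, so their numbers cannot be traced to a single change. For compound 3 the result is < 6, a limit of the assay rather than a number, which puts it at the limit of < 6 in this assay, at which 1 of the 3 values shown sits. Among the measured compounds shown here, the one measured single-site step, a number at least 0.62 log units lower from compound 2 to compound 3 (beyond the scatter), is the change that ends at this limit. Compound 4 differs from compound 3 by cyclopropyl in place of isopropyl on an aromatic nitrogen. For the measured compounds named here, no measured step changes this group alone; compounds 1 and 2 carry the two groups but also differ elsewhere, so they bear on the step only loosely. The step of a number at least 0.10 log units higher from compound 3 to compound 4 (that floor lies within the scatter) is therefore expected to be modest and uncertain in direction. Compound 4 is expected to give 6.1, with a range from 5.4 to 6.8, and a real chance of another limit.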

Compound 4, negative logarithm of the antagonist equilibrium constant: 6.4
The estimate for compound 4 lay 0.30 log units below the measured number; the range from low to high includes it.
By their numbers in this assay, from the lowest: compounds 4 and 2 (each within the scatter of the next); then compound 1. At a limit, below all of these: compound 3.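

Cyclopropyl in place of isopropyl on an aromatic nitrogen can now be read alone, and the change gives a number at least 0.40 log units higher from compound 3 to compound 4 (beyond the scatter). Compound 3 stands at a limit of the assay rather than at a number, so this step is only a floor: the limit of < 6 in this assay, at which 1 of the 4 values shown sits.

With cyclopropyl on the aromatic nitrogen, (4-methylpiperazin-1-yl)methyl in place of 4-propylpiperazin-1-yl on the saturated chain carbon gives a number 1.06 log units lower from compound 1 to compound 4 (beyond the scatter), a full number for a change of this kind, whereas the earlier step of this kind ended at a limit.

The compounds shown leave open how a cyclobutyl group on that aromatic nitrogen would compare. They also do not separate how much of the large step belongs to the chain and how much to the group on the piperazine.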